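The compounds below may be only part of what the source reports. "The series", "measured", "known", "first", "only" and "open" are said of these compounds alone.

In a functional assay on NCI-H146 cells (Homo sapiens) for cytotoxicity, with a stated time of 48 h, in the presence of a further agent that is not named here (on this read-out lower numbers stand for an effect already at smaller amounts and higher numbers for an effect only at larger amounts of compound), compound 1 (`CN(C)CC[C@H](CSc1ccccc1)Nc1ccc(S(=O)(=O)NC(=O)c2ccc(N3CCN(Cc4ccccc4-c4ccc(Cl)cc4)CC3)cc2)cc1C(F)(F)F`) gives 2460 nM, while compound 2 (`Cc1cc(S(=O)(=O)NC(=O)c2ccc(N3CCN(Cc4ccccc4-c4ccc(Cl)cc4)CC3)cc2)ccc1N[C@H](CCN(C)C)CSc1ccccc1`) gives 28800 nM, the highest of the two numbers. Compound 3 (`CN(C)CC[C@H](CSc1ccccc1)Nc1ccc(S(=O)(=O)NC(=O)c2ccc(N3CCN(Cc4ccccc4-c4ccc(Cl)cc4)CC3)cc2)cc1`) differs from compound 2 by hydrogen in place of methyl on an aromatic carbon. Going by the values given here, one measured step bears on this same place: a 12-fold higher number from compound 1 to compound 2 (1.07 log units; beyond the scatter), a large step beyond the scatter. Among the compounds with values here, no measured step covers hydrogen there, so the expectation is loose: a smaller move in this assay, towards a lower number. The expected change is a 2.9-fold lower number from compound 2 to compound 3 (0.46 log units; beyond the scatter). For compound 3 the estimate is 10000 nM, with an expected range of 2500 nM to 35000 nM.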

Compound 3, half-maximal effective concentration: 78700 nM
For compound 3 the middle estimate is 7.9-fold (0.90 log units) below the measured one; the measured number lies above the stated range.
By their numbers in this assay, from the lowest: compound 1; then compound 2; then compound 3.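

In this assay, removing the methyl group from this aromatic carbon gives a 2.7-fold higher number from compound 2 to compound 3 (0.44 log units; beyond the scatter), so the methyl group still lowers the number relative to no substituent at all. Hydrogen in place of trifluoromethyl gives a 32-fold higher number from compound 1 to compound 3 (1.51 log units; beyond the scatter), which sets the span of this position across the three compounds, with trifluoromethyl lowest and hydrogen highest. Nothing available here bears on what lies behind this order. Going by these compounds, whether a chlorine atom, a nitrile or a methoxy group at this carbon would fall below trifluoromethyl remains open.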